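Dropping the Chloro Group on the Way to Compound 4

The source may report more compounds than this note shows. Statements on the series, on what has been measured and on what is new or still open speak of the compounds shown alone.

Of the compounds shown here, three have been measured in a functional assay on NCI-H460 cells (Homo sapiens) for antiproliferative activity, read by MTT assay, with a stated time of 48 h; on this read-out lower numbers stand for stronger inhibition and higher numbers for weaker inhibition. Compound 1 `COc1ccccc1C(=O)Nc1nnc(SCC(=O)Nc2c(C)ccnc2Cl)s1` reaches only the limit of the assay, > 80000 nM, and so returns no number. Compound 2 `O=C(CSc1nnc(NC(=O)CCl)s1)Nc1ccc(Cl)cn1` gives 5700 nM, while compound 3 `O=C(CCl)Nc1ccc(SCC(=O)Nc2ccc(Cl)cn2)cc1` gives 420 nM. Among the two numbers actually recorded, compound 3 stands lowest, and the gap to compound 2 lies beyond the scatter of the assay, so compound 3 is the stronger inhibitor of the two; compound 1 contributes only a limit of > 80000 nM in this assay, at which 1 of the 3 values shown sits, and cannot be ranked against them.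

Compound 4 `O=C(CCl)Nc1ccc(SCC(=O)Nc2ccccn2)cc1` differs from compound 3 in a single place: hydrogen in place of chloro on an aromatic carbon. Among the compounds with values here, no pair of measured compounds differing only in this way is available, so the size of the step has to be judged from the change alone. Removing one chlorine from the pyridin-2-yl amide is a small alteration, and the expectation is a modest move towards weaker inhibition, on the edge of the usual scatter rather than far beyond it. The step from compound 3 to compound 4 in this assay is therefore estimated as a 2.4-fold higher number from compound 3 to compound 4 (0.38 log units; beyond the scatter). On that basis compound 4 is expected to give about 1000 nM in this assay, with a plausible range from 300 nM to 3500 nM.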

Compound 4, half-maximal inhibitory concentration: 11900 nM
Beside the measured number, compound 4's estimate is 12-fold (1.08 log units) below it, outside the stated range (above it).
By their numbers in this assay, from the lowest: compound 3; then compound 2; then compound 4. At a limit, above all of these: compound 1.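

Within the data shown here, this is the first pair that differs in one place only, and it shows that the chloro group of the 5-chloropyridin-2-yl amide carries real weight in this assay (a 28-fold higher number from compound 3 to compound 4 (1.45 log units; beyond the scatter)). Only one chlorine leaves and one hydrogen enters, with no change in rings, hydrogen-bond donors, hydrogen-bond acceptors or net charge, so this large step belongs entirely to a single aromatic carbon, two atoms from the ring nitrogen and para to a large group. Nothing available here bears on the reason for the size of this step.

The compounds shown leave open whether chlorine itself matters at this place, or whether a bromo group, a methyl group or an amine there would keep the number close to that of compound 3. They also leave open whether hydrogen in place of chloro would give a step of similar size on the core of compound 2.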